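This account rests on a few compounds, and the source may have more. Where it says the series, first, only, none or still open, it means among the compounds named here.

Compounds 1 to 3 share one core and were compared in a physicochemical assay for solubility, in phosphate buffer, at pH 6.5; on this read-out lower numbers stand for lower solubility and higher numbers for higher solubility. Compound 3 `Nc1nc(NC2CCNC2)c2sc(-c3ccc(C(F)(F)F)cc3)cc2n1` gives 155 ug/mL, the highest of the two numbers obtained. Compound 2 `Nc1nc(NC2CCCNC2)c2sc(-c3ccc(C(F)(F)F)cc3)cc2n1` gives 125 ug/mL, and the step of a 1.2-fold higher number from compound 2 to compound 3 (0.09 log units; within the scatter) is too small to count as a real difference. Compound 1 `CNc1nc(NC2CCOCC2)c2sc(-c3ccc(C(F)(F)F)cc3)cc2n1` yields only a limit of the assay, < 5 ug/mL, so no number is known for it.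

Compound 4 `Nc1nc(NC2CCOCC2)c2sc(-c3ccc(C(F)(F)F)cc3)cc2n1` differs from compound 3 in one place: oxan-4-yl in place of pyrrolidin-3-yl on a nitrogen on an aromatic ring. Within the data shown here, of the measured steps, only the one from compound 2 to compound 3 touches the same nitrogen, and there one ring bearing a nitrogen gave way to another ring bearing a nitrogen without a change beyond the scatter. It does not test what happens when that ring nitrogen is replaced by an oxygen. Among the measured compounds shown here, compound 1 also carries oxan-4-yl on this nitrogen and sits at the limit of < 5 ug/mL in this assay, at which 1 of the 3 values shown sits, but it carries in addition a methyl on the other amino group, so no single step to compound 4 can be drawn from it. The expectation is nonetheless that compound 4 falls well below compound 3, by about a 19-fold lower number from compound 3 to compound 4 (1.29 log units; beyond the scatter). Compound 4 is estimated at 8 ug/mL, with a likely range from 2 ug/mL to 30 ug/mL, and a fair chance that this assay reports only a limit.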

Compound 4, solubility: < 5 ug/mL
Compound 4: no number, only a limit; the forecaster's own chance of this, stated with the estimate: 40%; at least 1.6-fold (0.20 log units) between middle value and limit.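

The earlier step, a 1.2-fold higher number from compound 2 to compound 3 (0.09 log units; within the scatter), showed that on this nitrogen on an aromatic ring one ring bearing a nitrogen can stand in for another without a change beyond the scatter. Oxan-4-yl behaves differently in this assay: the result is an at least 31-fold lower number from compound 3 to compound 4 (1.49 log units; beyond the scatter), and an at least 25-fold lower number from compound 2 to compound 4 (1.39 log units; beyond the scatter), so the position does respond strongly to the group placed there. Compound 4 gives only a limit of the assay rather than a number, which means these steps fix how large the fall is at the least and not its full size, and compound 1 sits at that same limit: the limit of < 5 ug/mL in this assay, at which 2 of the 4 values shown sit.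

Going by these compounds, the step from compound 1 to compound 4 cannot be read, so what the methyl on the other amino group does stays open. A piperidin-4-yl group on this nitrogen, with the ring size of oxan-4-yl and a nitrogen in place of its oxygen, would show whether the fall goes with the loss of the ring nitrogen or with the change of ring and attachment.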